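A few compounds are considered here, and "the series" means these few. Any claim that something is new, unique, unknown or untested is made for them only; others in the source may bear on it.

Measured compounds: compound 1 `COc1ccc(Nc2nc(/C=C/c3cc(OC)c(OC)c(OC)c3)nc3ccsc23)cc1`, 279000 nM; compound 2 `COc1cc(/C=C/c2nc(Nc3ccc(C(F)(F)F)cc3)c3sccc3n2)cc(OC)c1OC`, 436000 nM; compound 3 `COc1cc(/C=C/c2nc(NCc3ccccc3)c3sccc3n2)cc(OC)c1OC`, 1800000 nM.

All three were tested in an ADME assay on L02 cells (Homo sapiens) for cytotoxicity, read by MTT assay; a lower number here means a stronger inhibitor, a higher number a weaker inhibitor. Compound 3 gives the highest number of the three, so it is the weakest inhibitor here: the step of a 6.5-fold higher number from compound 1 to compound 3 (0.81 log units; beyond the scatter) and the step of a 4.1-fold higher number from compound 2 to compound 3 (0.62 log units; beyond the scatter) both lie beyond the scatter. Compound 4 `COc1cc(/C=C/c2nc(NCc3ccc(C)cc3)c3sccc3n2)cc(OC)c1OC` differs from compound 3 by methyl in place of hydrogen on an aromatic carbon. For the measured compounds named here, no measured step changes only a single small group on the ring attached to the nitrogen; the closest comparison is a 1.6-fold higher number from compound 1 to compound 2 (0.19 log units; within the scatter), which swapped one such group for another and stayed within the scatter. On that basis compound 4 is expected to stay close to compound 3, with a step of no change at the digits printed from compound 3 to compound 4 (within the scatter), and its estimated value is 1800000 nM (range 700000 nM to 4500000 nM).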

Compound 4, half-maximal inhibitory concentration: 2930000 nM
Compound 4: middle estimate off by 1.6-fold (0.21 log units), on the low side; the measured number falls inside the stated range.
By their numbers in this assay, from the lowest: compounds 1 and 2 (each within the scatter of the next); then compounds 3 and 4 (each within the scatter of the next).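

In this assay, methyl on the ring of the benzyl group, turning benzyl into 4-methylbenzyl, gives a 1.6-fold higher number from compound 3 to compound 4 (0.21 log units; within the scatter), so at this ring position methyl cannot be told apart from hydrogen. The gap to the phenyl compounds remains: 4-methylbenzyl in place of 4-(trifluoromethyl)phenyl gives a 6.7-fold higher number from compound 2 to compound 4 (0.83 log units; beyond the scatter), and in place of 4-methoxyphenyl gives an 11-fold higher number from compound 1 to compound 4 (1.02 log units; beyond the scatter). Nothing available explains these gaps. On these data alone, whether a hydroxyl or an amine on this same ring carbon, or a longer chain in place of benzyl, would shift the number remains open.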